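The compounds below may be only part of what the source reports. "The series", "measured", "known", "first", "only" and "open" are said of these compounds alone.

Compound 1 `CN(c1ccncc1)n1cccc1`: > 20 mg/kg
Compound 2 `CN(c1ccncc1)n1cccc1CO`: > 20 mg/kg

In a functional assay on the whole organism with Mus musculus as the target (on this read-out lower numbers stand for an effect already at smaller amounts and higher numbers for an effect only at larger amounts of compound), compound 1 gives > 20 mg/kg, which is a limit of the assay and not a number. In this assay, compound 2 gives > 20 mg/kg, which is also only a limit. So compound 2 has no exact position on this scale, and the whole measured set stands at the limit of > 20 mg/kg in this assay, at which 2 of the 2 values shown sit.

Compound 3 `CC(O)c1cccn1N(C)c1ccncc1` differs from compound 2 by methyl in place of hydrogen on a saturated chain carbon bound to an aromatic carbon and an oxygen on a saturated carbon, turning hydroxymethyl into 1-hydroxyethyl. Among the compounds with values here, the only measured step that bears on this change is a step that the two limits leave unreadable from compound 1 to compound 2. It involves the same hydroxymethyl group but offers no size to carry forward. No step beyond the usual scatter is therefore expected, in either direction, and another limit is the likeliest result. The expected change is a step that the limit leaves unreadable from compound 2 to compound 3. For compound 3, the estimated value is 25 mg/kg, with an expected range from 10 mg/kg to 60 mg/kg.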

Compound 3, dose for half-maximal effect: > 20 mg/kg
Compound 3 ended at the assay's limit; the forecaster's own chance of this, stated with the estimate: 75%; the middle value is on the limit's open side.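

Compound 3 also gives only a limit of the assay and not a number, so the steps from compound 1 and compound 2 to compound 3 cannot be read in this assay: the limit of > 20 mg/kg in this assay, at which 3 of the 3 values shown sit. The compounds shown leave open whether hydroxymethyl or 1-hydroxyethyl changes the dose for half-maximal effect at all.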